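Chain lengthening on the sulfonamide arm of compound 3

This account rests on a few compounds, and the source may have more. Where it says the series, first, only, none or still open, it means among the compounds named here.

Compound 3 `CC(C)(C)c1ccc(C(=O)N2CCC3(CC2)C(=O)N(CC(=O)NCCCNS(C)(=O)=O)CN3c2ccccc2)cc1` gives 10400 nM in an assay on HEK293 cells for displacement of a labelled ligand from NPC1-like intracellular cholesterol transporter 1 (Homo sapiens) (on this read-out higher numbers stand for weaker inhibition and lower numbers for stronger inhibition), the second highest of the three numbers. Compound 1 `CC(C)(C)c1ccc(C(=O)N2CCC3(CC2)C(=O)N(CC(=O)N2CCCC(O)C2)CN3c2ccccc2)cc1` gives 12200 nM in this assay, and a 1.2-fold lower number from compound 1 to compound 3 (0.07 log units; within the scatter) lies within the scatter. Within the data shown here, compound 2 `CC(C)(C)c1ccc(C(=O)N2CCC3(CC2)C(=O)N(CC(=O)NCNS(C)(=O)=O)CN3c2ccccc2)cc1` gives 3200 nM in this assay, so a 3.3-fold higher number from compound 2 to compound 3 (0.51 log units; beyond the scatter) is the only step beyond the scatter that touches compound 3. Compound 4 `CC(C)(C)c1ccc(C(=O)N2CCC3(CC2)C(=O)N(CC(=O)NCCCCNS(C)(=O)=O)CN3c2ccccc2)cc1` carries (methanesulfonamido)methyl in place of methanesulfonamido on a saturated chain carbon, three bonds along the chain from an amide-type nitrogen. Among the measured compounds shown here, the one comparable step is a 3.3-fold higher number from compound 2 to compound 3 (0.51 log units; beyond the scatter), a lengthening of the same arm that weakened the number modestly; the change to compound 4 is the same difference cut one bond further out. A small upward step is therefore expected, a 1.4-fold higher number from compound 3 to compound 4 (0.16 log units; within the scatter), possibly no larger than the scatter. Compound 4 is estimated at 15000 nM, with a range from 6000 nM to 38000 nM.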

Compound 4, half-maximal inhibitory concentration: 4500 nM
Compound 4: the middle estimate sits 3.3-fold (0.52 log units) above what was measured, and the stated range ends above it.
By their numbers in this assay, from the lowest: compounds 2 and 4 (each within the scatter of the next); then compounds 3 and 1 (each within the scatter of the next).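

At this chain carbon, lengthening does not act in one direction: the step to the butyl chain (a 2.3-fold lower number from compound 3 to compound 4 (0.36 log units; beyond the scatter)) runs opposite to the earlier lengthening, so compound 3 goes against any steady trend with chain length. The butyl chain cannot be told apart from the shortest arm (a 1.4-fold higher number from compound 2 to compound 4 (0.15 log units; within the scatter)). It also improves on the 3-hydroxypiperidin-1-yl amide (a 2.7-fold lower number from compound 1 to compound 4 (0.43 log units; beyond the scatter)).

From the compounds shown here alone, whether a longer chain, or an amine or carboxylic acid in place of methanesulfonamido, would shift the number remains open. Nothing available explains the non-steady response to chain length.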